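The source may report more compounds than this note shows. Statements on the series, on what has been measured and on what is new or still open speak of the compounds shown alone.

In a physicochemical assay for lipophilicity, at pH 7.4 (a lower number here means a more polar compound, a higher number a more lipophilic compound), compound 1 (`Cc1cc(C(=O)NCc2cccnc2)nn1Cc1cc(Cl)ccc1OCc1ccccc1`) gives > 3.7, which is a limit of the assay and not a number. Compound 2 (`Cc1cc(NC(=O)c2ccccc2)nn1Cc1cc(Cl)ccc1OCc1ccccc1`) gives > 3.7, which is also a limit. Both therefore stand at the limit of > 3.7 in this assay, at which 2 of the 2 values shown sit, and compound 2 has no exact value. Compound 3 (`Cc1cc(NC(=O)OC(C)(C)C)nn1Cc1cc(Cl)ccc1OCc1ccccc1`) differs from compound 2 as follows: tert-butoxy in place of phenyl on a carbonyl carbon. Tert-butoxy takes the place of phenyl on a carbonyl carbon, turning benzamido into (tert-butoxycarbonyl)amino. Going by the values given here, the only measured step that bears on this change is a step that the two limits leave unreadable from compound 1 to compound 2, so it offers neither a size nor a direction to carry over. With so little to go on, no clear shift in either direction is expected, and the estimated step is a step that the limit leaves unreadable from compound 2 to compound 3. For compound 3 the expected value in this assay is 4.1, with an estimated range of 3.6 to 4.7.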

Compound 3, distribution coefficient: > 3.7
Compound 3 was reported as a limit; the forecaster's own chance of this, stated with the estimate: 75%; the middle value is on the limit's open side.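

Compound 3 is reported only as a limit and not a number, so no step linking it to compound 1 or compound 2 can be read in this assay: the limit of > 3.7 in this assay, at which 3 of the 3 values shown sit.

The compounds shown leave open how compound 1, compound 2 and compound 3 actually rank against one another in this assay.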